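A few compounds are considered here, and "the series" means these few. Any claim that something is new, unique, unknown or untested is made for them only; others in the source may bear on it.

Of the compounds shown here, two built on one shared core have been tested in a toxicity assay on MT2 cells (Homo sapiens) for cytotoxicity, read by XTT assay, with a stated time of 4 days; on this read-out lower numbers stand for higher toxicity in this test and higher numbers for lower toxicity in this test. Compound 1 `Cc1nc(C)c([C@H](OC(C)(C)C)C(=O)O)c(N2CCC(C)(C)CC2)c1-c1ccc(OCCc2ccc(Cl)cc2)cc1` carries a 4-chlorophenyl group at the end of its ethoxy chain. In this assay compound 1 gives >= 33500 nM, which is a limit of the assay and not a number. Compound 2 `Cc1nc(C)c([C@H](OC(C)(C)C)C(=O)O)c(N2CCC(C)(C)CC2)c1-c1ccc(OCCc2ccc(F)c(F)c2)cc1` carries a 3,4-difluorophenyl group in its place. In this assay compound 2 gives >= 33500 nM, again a limit rather than a number. The step that the two limits leave unreadable from compound 1 to compound 2 therefore cannot be read in size or direction, since (the limit of >= 33500 nM in this assay, at which 2 of the 2 values shown sit).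

Compound 3 `Cc1nc(C)c([C@H](OC(C)(C)C)C(=O)O)c(N2CCC(C)(C)CC2)c1-c1ccc(OCCc2ccncc2)cc1` is the next member: pyridin-4-yl in place of 3,4-difluorophenyl on a saturated chain carbon, two bonds along the chain from an oxygen on an aromatic ring. Going by the values given here, the one measured step bears on this change only in that both of its partners sit at the same limit, so no step beyond the scatter is expected, and the expected change is a number no higher from compound 2 to compound 3 (the limit leaves the size open). Compound 3 is estimated at 33500 nM, within a range from 15000 nM to 70000 nM, and is expected most likely to be reported again as a limit.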

Compound 3, half-maximal cytotoxic concentration: >= 25000 nM
Compound 3 ended at the assay's limit (the forecaster's own chance of this, stated with the estimate: 85%); the middle value is on the limit's open side.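

Compound 3 also ends at a limit in this assay, not at a number, so the steps to it from compound 1 and compound 2 cannot be read: the limit of >= 25000 nM in this assay, at which 1 of the 3 values shown sits. The three compounds leave open what concentration would harm these cells, and whether changing the ring at the end of the chain alters it.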